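From (5-hydroxypentyl)amino to bis(2-hydroxyethyl)amino on a Carbonyl Carbon

This account rests on a few compounds, and the source may have more. Where it says the series, first, only, none or still open, it means among the compounds named here.

Compound 1 `COc1cc(NC(C)CCCNC(=O)NNC(=O)NCCCCCO)c2ncccc2c1` is the starting point here, and it was tested in a functional assay on HeLa cells (Homo sapiens) for inhibition, read by MTT assay, with a stated time of 4 days; a lower number here means a stronger inhibitor, a higher number a weaker inhibitor. In this test, compound 1 gives >= 250000 nM, which is a limit of the assay and not a number. So its true potency is unknown, and only a limit can anchor the comparison. Compound 2 `COc1cc(NC(C)CCCNC(=O)NNC(=O)N(C)C(c2ccccc2)c2ccccc2)c2ncccc2c1` gives an actual number in the same test, 22000 nM.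

Compound 3 `COc1cc(NC(C)CCCNC(=O)NNC(=O)N(CCO)CCO)c2ncccc2c1` keeps the core of compound 1 and changes one group: bis(2-hydroxyethyl)amino takes the place of (5-hydroxypentyl)amino on a carbonyl carbon (bis(2-hydroxyethyl)amino in place of (5-hydroxypentyl)amino on a carbonyl carbon). Among the measured compounds shown here, no measured pair of compounds shows what a change of this kind does, so any forecast is uncertain. Neither group contains a ring, and the count of heavy atoms stays the same. Little movement is therefore expected, with compound 3 most likely staying a very weak inhibitor, close to the limit seen for compound 1. The estimated step is a number no higher from compound 1 to compound 3 (the limit leaves the size open), no larger than the usual scatter. For compound 3, the expected value is 250000 nM, within an estimated range of 100000 nM to 500000 nM.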

Compound 3, half-maximal inhibitory concentration: > 250000 nM
Compound 3 ended at the assay's limit (the forecaster's own chance of this, stated with the estimate: 70%); the middle value lies on the limit itself.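

Among the compounds shown here, compound 1 and compound 3 both end at a limit of this assay, not at a number, and no step between them can be read. The compounds shown leave open how weak each of the two truly is, and whether (5-hydroxypentyl)amino or bis(2-hydroxyethyl)amino on a carbonyl carbon gives the stronger inhibitor.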